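The source may hold more compounds than are shown below. What is called first, only, known or untested is meant among the compounds shown, and "the series" means these compounds.

Compound 1 `Cc1cc(C)c(Oc2cc(Nc3ccc(C#N)cc3)ncc2C(=O)NCc2cn(Cc3ccccc3[N+](=O)[O-])nn2)c(C)c1`, compound 2 `Cc1cc(C)c(Oc2cc(Nc3ccc(C#N)cc3)ncc2C(=O)NCc2cn(Cc3ccccc3Cl)nn2)c(C)c1` and compound 3 `Cc1cc(C)c(Oc2cc(Nc3ccc(C#N)cc3)ncc2C(=O)NCc2cn(Cc3ccc(Cl)cc3)nn2)c(C)c1` share one core and differ only in the group on a saturated chain carbon bound to an aromatic nitrogen; compound 4 `Cc1cc(C)c(Oc2cc(Nc3ccc(C#N)cc3)ncc2C(=O)NCc2cn(Cc3ccc([N+](=O)[O-])cc3)nn2)c(C)c1` has not yet been measured. In an ADME assay on MT4 cells (Homo sapiens) for cytotoxicity, read by MTT assay, with a stated time of 5 days (on this read-out lower numbers stand for higher toxicity in this test and higher numbers for lower toxicity in this test), compound 1 gives > 212000 nM, which is a limit of the assay. In this assay compound 2 gives >= 188000 nM, also a limit. In this assay compound 3 gives >= 120000 nM, again a limit. The cores of compound 2 and compound 3 differ by 4-chlorophenyl in place of 2-chlorophenyl on a saturated chain carbon bound to an aromatic nitrogen. The change nitro in place of chloro on an aromatic carbon on compound 2 gives a step that the two limits leave unreadable from compound 2 to compound 1. Compound 4 differs from compound 3 by nitro in place of chloro on an aromatic carbon, the same kind of change, though here the place reads para to a large group rather than ortho to a large group. Because compound 3 sits at the limit of >= 120000 nM in this assay, at which 1 of the 3 values shown sits, compound 4 is expected to show a step that the limit leaves unreadable from compound 3 to compound 4 in this assay. Compound 4 is therefore estimated at 180000 nM in this assay.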

Compound 4, half-maximal cytotoxic concentration: >= 139000 nM
Compound 4: no number, only a limit; the forecaster's own chance of this, stated with the estimate: 85%; the middle value lies beyond the limit too.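

In this assay, among these compounds, compound 1, compound 2, compound 3 and compound 4 all stand as limits, so no step among them can be read. The compounds shown leave open whether nitro in place of chloro changes the read-out at all.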